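The compounds below may be only part of what the source reports. "The series", "measured", "known", "first", "only" and "open" are said of these compounds alone.

Of the compounds shown here, three built on one shared core have been measured in a functional assay on cells for inhibition of growth hormone secretagogue receptor type 1 (Homo sapiens), read by FLIPR and calcium flux; a lower number here means that less compound is needed, a higher number that more compound is needed for the effect. Compound 1 `CC(C)(N)C(=O)N[C@H](COCc1cccc(Cl)c1)c1nnnn1CCOC(=O)NCCCCO` gives 1.6 nM, compound 2 `CC(C)(N)C(=O)N[C@H](COCc1cccc(Cl)c1Cl)c1nnnn1CCOC(=O)NCCCCO` gives 0.61 nM, and compound 3 `CC(C)(N)C(=O)N[C@H](COCc1ccccc1C(F)(F)F)c1nnnn1CCOC(=O)NCCCCO` gives 0.72 nM. Compound 3 therefore holds the second highest of the three numbers in this assay: the step of a 1.2-fold higher number from compound 2 to compound 3 (0.07 log units; within the scatter) lies within the scatter, while the step of a 2.2-fold lower number from compound 1 to compound 3 (0.35 log units; beyond the scatter) lies beyond it.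

Compound 4 `CC(C)(N)C(=O)N[C@H](COCc1cccc(OC(F)(F)F)c1)c1nnnn1CCOC(=O)NCCCCO` differs from compound 3 by 3-(trifluoromethoxy)phenyl in place of 2-(trifluoromethyl)phenyl on a saturated chain carbon bound to an oxygen on a saturated carbon. For the measured compounds named here, two measured steps bear on this kind of exchange, since both replace the aryl group at the same place: a 2.2-fold lower number from compound 1 to compound 3 (0.35 log units; beyond the scatter) was modest, and a 1.2-fold higher number from compound 2 to compound 3 (0.07 log units; within the scatter) did not exceed the scatter. The remaining step, a 2.6-fold lower number from compound 1 to compound 2 (0.42 log units; beyond the scatter), was also modest. Exchanges of the aryl group have so far moved the number in this assay only slightly, so for the step to compound 4 no change beyond the scatter is expected, a 1.5-fold higher number from compound 3 to compound 4 (0.18 log units; within the scatter). Compound 4 is accordingly estimated at 1.1 nM in this assay, with a range from 0.45 nM to 3 nM.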

Compound 4, half-maximal effective concentration: 3.1 nM
Compound 4: middle estimate off by 2.8-fold (0.45 log units), on the low side, and the stated range ends below it.
By their numbers in this assay, from the lowest: compounds 2 and 3 (each within the scatter of the next); then compounds 1 and 4 (each within the scatter of the next).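

In this assay, for the compounds shown here, this aryl exchange produces larger shifts than any earlier step, with a 4.3-fold higher number from compound 3 to compound 4 (0.63 log units; beyond the scatter) and a 5.1-fold higher number from compound 2 to compound 4 (0.71 log units; beyond the scatter), so the group at this place can matter more than the earlier compounds suggested. By contrast, trifluoromethoxy in place of chloro on an aromatic carbon gives a 1.9-fold higher number from compound 1 to compound 4 (0.29 log units; within the scatter), so 3-(trifluoromethoxy)phenyl and 3-chlorophenyl are not told apart, while 2,3-dichlorophenyl and 2-(trifluoromethyl)phenyl both give lower numbers than either of them. Nothing available here accounts for these differences.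

From the compounds shown here alone, it remains open how 3-(trifluoromethyl)phenyl or 2-(trifluoromethoxy)phenyl would read at this place, which would separate the effect of the group from that of its ring position. Also open, going by these compounds, is how an amine or a carboxylic acid on the aromatic ring would read in this assay.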